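Cytotoxicity in Colon Cells: Compound 3 to Compound 4

The compounds below may be only part of what the source reports. "The series", "measured", "known", "first", "only" and "open" are said of these compounds alone.

Measured so far in an ADME assay on NCM460 cells (Homo sapiens) for cytotoxicity, read by CCK-8 assay, with a stated time of 48 h; on this read-out higher numbers stand for weaker inhibition and lower numbers for stronger inhibition:
Compound 1 `COc1ccc(/C=C\c2cc(OC)c(OC)c(OC)c2)cc1OCc1ccc(CN2CC(C(=O)O)C2)cc1` gives > 50000 nM, a limit of the assay.
Compound 2 `COc1ccc(/C=C\c2cc(OC)c(OC)c(OC)c2)cc1OCc1ccc(CN2C[C@H](O)C[C@@H]2C(=O)O)cc1` gives > 50000 nM, also a limit.
Compound 3 `COc1ccc(/C=C\c2cc(OC)c(OC)c(OC)c2)cc1OCc1ccc(CN2CCCCC2C(=O)NCCN)cc1` gives > 50000 nM, again a limit.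

Compound 3 therefore stands where every measured compound stands: at the limit of > 50000 nM in this assay, at which 3 of the 3 values shown sit. The steps a step that the two limits leave unreadable from compound 1 to compound 2, a step that the two limits leave unreadable from compound 1 to compound 3 and a step that the two limits leave unreadable from compound 2 to compound 3 all ended at limits, so none of them can be read in size or direction.

Compound 4 `COc1ccc(/C=C\c2cc(OC)c(OC)c(OC)c2)cc1OCc1ccc(CN[C@H](C(=O)O)[C@@H](C)O)cc1` differs from compound 3 by (1-carboxy-2-hydroxypropyl)amino in place of 2-((2-aminoethyl)carbamoyl)piperidin-1-yl on a saturated chain carbon bound to an aromatic carbon. Among the measured compounds shown here, no measured step bears readably on this change. For the measured compounds named here, since every compound so far sits at the limit, compound 4 is expected to sit there too, meaning a step that the limit leaves unreadable from compound 3 to compound 4. In this assay compound 4 is estimated at 80000 nM, within 30000 nM to 250000 nM.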

Compound 4, half-maximal inhibitory concentration: > 50000 nM
Compound 4: no number, only a limit; the forecaster's own chance of this, stated with the estimate: 85%; the middle value does not contradict the limit.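

Compound 4 also gives only a limit, so none of the steps linking it to compound 1, compound 2 or compound 3 can be read: the limit of > 50000 nM in this assay, at which 4 of the 4 values shown sit. The compounds shown leave open whether any of these group changes alters cytotoxicity at all.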